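The compounds below may be only part of what the source reports. "The series", "measured", "known", "first", "only" and "open" are said of these compounds alone.

Measured compounds: compound 1 `NNC(=O)CCc1ccncc1-c1ccc2ccccc2c1`, compound 2 `O=C(COc1ccncc1-c1ccc2ccccc2c1)N1CCOCC1`, compound 3 `COC(=O)/C=C/c1ccncc1-c1ccc2ccccc2c1`.

In an assay on a protein complex for inhibition of CDK8/Cyclin C (Homo sapiens), with a stated time of 1 h, tested at 10 uM (on this read-out lower numbers stand for less inhibition and higher numbers for more inhibition at the one concentration tested (going by the name of the read-out)), compound 1 gives 102%, compound 2 gives 9%, and compound 3 gives 102%. Compound 3 thus stands level with compound 1, the pair together the highest of the three, while compound 2 lies far lower. For the measured compounds named here, the only single-site step measured, no change at the digits printed from compound 1 to compound 3 (within the scatter), shows the read-out unmoved by that exchange. Compound 4 `CNC(=O)COc1ccncc1-c1ccc2ccccc2c1` differs from compound 3 at the same place: (methylcarbamoyl)methoxy in place of 2-(methoxycarbonyl)ethenyl on an aromatic carbon. Going by the values given here, no measured step bears directly on this exchange, but compound 2, whose own side chain resembles the one entering, shows a low value. The step of a number 62 percentage points lower from compound 3 to compound 4 (beyond the scatter) is therefore expected to be downward, though with wide uncertainty. Compound 4 is estimated at 40%, between 5% and 90%.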

Compound 4, a percentage reported as inhibition, at one concentration (the size of the read-out at that concentration, not a potency): 4%
Estimate against measurement, compound 4: 36 percentage points above; the whole stated range lies above it.
By their numbers in this assay, from the lowest: compounds 4 and 2 (each within the scatter of the next); then compounds 1 and 3 (each within the scatter of the next).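

In this assay, the steps of a number 98 percentage points lower from compound 3 to compound 4 (beyond the scatter) and a number 98 percentage points lower from compound 1 to compound 4 (beyond the scatter) show that this place on the aromatic carbon, opposite the ring nitrogen, does not accept every side chain of this size: (methylcarbamoyl)methoxy does not keep the high read-out seen with the two earlier groups. The step of a number 5 percentage points lower from compound 2 to compound 4 (within the scatter), methylamino in place of morpholin-4-yl, shows that the read-out stays low with either group on the carbonyl carbon. No measurement here gives a reason for the large drop. Still open, going by these compounds, is whether the low numbers follow the oxygen of the chain or its amide end, and whether (methoxycarbonyl)methoxy, an ester on the same oxygen-linked chain, would read like compound 3 or like compound 4.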